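This account rests on a few compounds, and the source may have more. Where it says the series, first, only, none or still open, it means among the compounds named here.

Measured so far:
- compound 1 `CCN(Cc1cccs1)C(=O)COc1ccc(C)cc1`: 8 nM in an assay on HEK293 cells for agonist activity at transient receptor potential cation channel subfamily M member 8 (Homo sapiens), read by fluorescence and calcium flux, with a stated time of 15 min; on this read-out lower numbers stand for an effect already at smaller amounts and higher numbers for an effect only at larger amounts of compound
- compound 2 `Cc1ccc(OCC(=O)N(Cc2cccs2)c2nccn2C)cc1`: 1790 nM in this assay

Compound 2 shows the highest number of the two. Within the data shown here, the only step known here, a 220-fold higher number from compound 1 to compound 2 (2.35 log units; beyond the scatter), came from putting a five-membered aromatic ring on the amide-type nitrogen in place of a short chain. Compound 3 `Cc1ccc(OCC(=O)N(Cc2cccs2)c2cnn(C)c2)cc1` keeps that ring type but changes it: 1-methyl-1H-pyrazol-4-yl in place of 1-methyl-1H-imidazol-2-yl on an amide-type nitrogen. Among the measured compounds shown here, no measured step describes such a swap of one ring for another, so the direction is open; the expected change is small, a 1.2-fold lower number from compound 2 to compound 3 (0.08 log units; within the scatter). Compound 3 is estimated at 1500 nM, with a range from 400 nM to 6000 nM.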

Compound 3, half-maximal effective concentration: 63000 nM
For compound 3 the middle estimate is 42-fold (1.62 log units) below the measured one; the measured number lies above the stated range.
By their numbers in this assay, from the lowest: compound 1; then compound 2; then compound 3.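

Both rings have the same atoms and the same counts of hydrogen-bond donors and acceptors, yet moving from 1-methyl-1H-imidazol-2-yl to 1-methyl-1H-pyrazol-4-yl gives a 35-fold higher number from compound 2 to compound 3 (1.55 log units; beyond the scatter) in this assay. At this amide-type nitrogen, then, how the ring is joined matters, not only which atoms it contains. Replacing ethyl with the pyrazole group gives a 7900-fold higher number from compound 1 to compound 3 (3.90 log units; beyond the scatter), and nothing shown explains the size of either step. Still open, going by these compounds, is whether a longer chain such as propyl would keep the low number of compound 1, and whether a phenyl ring would behave like either ring here.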